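Triazole-linked aryl ethers: compound 2 to compound 3

The source may hold more compounds than are shown below. What is called first, only, known or untested is meant among the compounds shown, and "the series" means these compounds.

Measured so far:
compound 1 `CS(=O)(=O)Nc1ccc(-n2cc(OCc3ccccc3)nn2)cc1Oc1ccccc1` — "not determined" (no result reported) in a functional assay on HeLa cells (Homo sapiens) for inhibition, read by MTT assay, with a stated time of 48 h; on this read-out lower numbers stand for stronger inhibition and higher numbers for weaker inhibition
compound 2 `CS(=O)(=O)Nc1ccc(-n2cc(COc3ccc4ccccc4c3)nn2)cc1Oc1ccccc1` — 12800 nM

Compound 2 carries the only number shown; compound 1 has no result, so no comparison to it can be drawn. Compound 3 `CS(=O)(=O)Nc1ccc(-n2cc(COc3ccccc3Cl)nn2)cc1Oc1ccccc1` differs from compound 2 by 2-chlorophenyl in place of naphthalen-2-yl on an oxygen on a saturated carbon. Within the data shown here, no step between measured compounds is available to gauge this change, so the expected step is small, in no firm direction, and likely within the scatter. For compound 3 the value in this assay is expected at 15000 nM (range 5000 nM to 50000 nM), the expected step being a 1.2-fold higher number from compound 2 to compound 3 (0.07 log units; within the scatter).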

Compound 3, half-maximal inhibitory concentration: 38600 nM
For compound 3 the middle estimate is 2.6-fold (0.41 log units) below the measured one; the range from low to high includes it.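

In this assay the swap of naphthalen-2-yl for 2-chlorophenyl on this oxygen gives a 3.0-fold higher number from compound 2 to compound 3 (0.48 log units; beyond the scatter) and thereby shows that this position responds to the group it carries, with the naphthalen-2-yl compound holding the lower number of this pair. The change removes one aromatic ring and adds a chlorine at once, so this pair cannot separate the two. Nothing available accounts for the step.

Still open, on these data alone, is how a plain phenyl would read here. A phenyl carrying a carboxylic acid or an amine is equally unresolved.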